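This account rests on a few compounds, and the source may have more. Where it says the series, first, only, none or still open, it means among the compounds named here.

Three compounds built on one shared core were tested in a functional assay on HCT-116 cells (Homo sapiens) for inhibition, read by sulforhodamine B assay, with a stated time of 48 h, tested at 50 uM; a higher number here means more inhibition of growth at the concentration tested, a lower number less inhibition of growth. Compound 1 `O=C1C(=O)N(CCCCn2cc(COc3cc(=O)oc4ccccc34)nn2)c2ccc(F)cc21` carries a fluoro group on an aromatic carbon and gives 67% in this assay. Compound 2 `O=C1C(=O)N(CCCCn2cc(COc3cc(=O)oc4ccccc34)nn2)c2ccc(Cl)cc21` carries a chloro group in its place; in this assay compound 2 gives 62%, and a number 5 percentage points lower from compound 1 to compound 2 (within the scatter). Compound 3 `COc1ccc2c(c1)C(=O)C(=O)N2CCCCn1cc(COc2cc(=O)oc3ccccc23)nn1`, with a methoxy group at that carbon, gives 48% in this assay, the lowest of the three numbers: the step of a number 19 percentage points lower from compound 1 to compound 3 (beyond the scatter) and the step of a number 14 percentage points lower from compound 2 to compound 3 (beyond the scatter) both fall beyond the scatter, so compound 3 stands clearly below the two compounds that bear a halogen.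

Compound 4 `O=C1C(=O)N(CCCCn2cc(COc3cc(=O)oc4ccccc34)nn2)c2ccc(I)cc21` has not yet been measured. Its change from compound 3 is iodo in place of methoxy on an aromatic carbon. Going by the values given here, two measured steps bear on this move, since each replaced a halogen with methoxy and each lowered the number: a number 19 percentage points lower from compound 1 to compound 3 (beyond the scatter) and a number 14 percentage points lower from compound 2 to compound 3 (beyond the scatter). The change to compound 4 runs the opposite way, from methoxy back to a halogen, so a rise of comparable size is expected. No iodo compound has been measured, and whether iodo follows fluoro or chloro is not shown by these data. Compound 4 is therefore expected to give 62% in this assay, within a range from 50% to 74%. This corresponds to an expected step of a number 14 percentage points higher from compound 3 to compound 4 (beyond the scatter).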

Compound 4, percent growth inhibition at one concentration: 57%
Estimate against measurement, compound 4: 5 percentage points above; measured number inside the range.
By their numbers in this assay, from the lowest: compounds 3, 4, 2 and 1 (each within the scatter of the next, the first and the last beyond it).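

At this aromatic carbon, the exchange of methoxy for iodo gives a number 9 percentage points higher from compound 3 to compound 4 (within the scatter) in this assay, so iodo does not stand clearly apart from methoxy in the way that fluoro and chloro did. Iodo does not stand clearly apart from the other two halogens either, with a number 5 percentage points lower from compound 2 to compound 4 (within the scatter) and a number 10 percentage points lower from compound 1 to compound 4 (within the scatter) in the same read-out, so compound 4 lies within the scatter of all three earlier compounds. The clear gap between halogen and methoxy therefore holds for compound 1 and compound 2 but not for compound 4, and no measurement shown here accounts for any of these differences.

The compounds shown leave open how a group of another kind at this carbon, such as an amine, a carboxylic acid or a nitrile, would compare with these four, and whether plain hydrogen there would sit with the halogens or with methoxy. They also leave open whether the small differences among the halogens would persist with a shorter or longer chain in place of the butylene link.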